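A few compounds are considered here, and "the series" means these few. Any claim that something is new, unique, unknown or untested is made for them only; others in the source may bear on it.

Three measured compounds share one core and differ only in the group that sits on the amide carbonyl. Compound 1 has the structure `COc1ccc(-c2cnc(NC(=O)c3ccc([N+](=O)[O-])cc3)n2C)cc1`. In a toxicity assay on THP-1 cells (Homo sapiens) for inhibition (on this read-out lower numbers stand for higher toxicity in this test and higher numbers for lower toxicity in this test), compound 1 reaches only the limit of the test, giving > 100000 nM. Compound 2 has the structure `COc1ccc(-c2cnc(NC(=O)CCc3ccccc3)n2C)cc1`. In this assay compound 2 again reaches only the limit, giving > 100000 nM. Compound 3 has the structure `COc1ccc(-c2cnc(NC(=O)c3ccccc3)n2C)cc1`. In this assay compound 3 likewise reaches only the limit, giving > 100000 nM. Compound 3 therefore stands at the limit, and no number places it above or below its two neighbours.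

The step to the unmeasured compound 4, `COc1ccc(-c2cnc(NC(=O)c3ccc(Cl)cc3)n2C)cc1`, is chloro in place of hydrogen on an aromatic carbon. Among the measured compounds shown here, two measured steps touch the same carbonyl substituent: a step that the two limits leave unreadable from compound 1 to compound 3 and a step that the two limits leave unreadable from compound 2 to compound 3; both stay unreadable because of the limit of > 100000 nM in this assay, at which 3 of the 3 values shown sit. Nothing here shows any change of toxicity on altering the aromatic group, so the expected step that the limit leaves unreadable from compound 3 to compound 4 is none beyond the scatter, with a high chance that the assay again reports only a limit. Compound 4 is estimated at 150000 nM, expected to fall between 50000 nM and 500000 nM.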

Compound 4, half-maximal cytotoxic concentration: > 100000 nM
Compound 4: no number, only a limit; the forecaster's own chance of this, stated with the estimate: 75%; the middle value is on the limit's open side.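

In this assay compound 4 gives > 100000 nM as a limit and not a number. Its steps from compound 1, compound 2 and compound 3 therefore cannot be read: the limit of > 100000 nM in this assay, at which 4 of the 4 values shown sit. The compounds shown leave open whether this assay would return an actual number for any other group on the amide carbonyl.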